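Hexylphenyl ketones at thyroid hormone receptor alpha: epoxide in place of acid

The source may hold more compounds than are shown below. What is called first, only, known or untested is meant among the compounds shown, and "the series" means these compounds.

Measured so far:
compound 1 `CCCCCCc1ccc(C(=O)/C=C\C(=O)O)cc1` — 19200 nM
compound 2 `C=CC(=O)[C@H]1CC[C@H](CC(C)(C)C)CC1` — 75600 nM
compound 3 `C=CC(=O)Oc1ccc(CCCCC)cc1` — > 100000 nM

In an assay on isolated protein for displacement of a labelled ligand from thyroid hormone receptor alpha (Homo sapiens), read by fluorescence polarization (a lower number here means a stronger inhibitor, a higher number a weaker inhibitor), compound 1 gives 19200 nM. Of the two numbers available it is the lower one; compound 2 gives 75600 nM, which lies beyond the usual scatter of this assay. For compound 3 the value > 100000 nM is a limit of the assay and not a number; the same limit is recorded in the limit of > 100000 nM in this assay, at which 1 of the 3 values shown sits. Within the data shown here, no step between two measured compounds is known here, so there is no measured change of this kind to lean on.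

Compound 4 `CCCCCCc1ccc(C(=O)C2CO2)cc1` is the unmeasured member. It differs from compound 1 by oxiran-2-yl in place of 2-carboxyethenyl on a carbonyl carbon. The hexylphenyl ketone core of compound 1 is kept. The change removes the carboxylic acid and puts in a small three-membered ring with one oxygen. With nothing measured in the series for this kind of exchange, the step from compound 1 to compound 4 is expected to be a 2.1-fold higher number from compound 1 to compound 4 (0.32 log units; beyond the scatter), towards a weaker inhibitor, though a result within the scatter of compound 1 cannot be ruled out.

Compound 4 is estimated at 40000 nM in this assay, with a range from 8000 nM to 100000 nM.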

Compound 4, half-maximal inhibitory concentration in the thyroid hormone receptor alpha assay: 33200 nM
Compound 4: the middle estimate sits 1.2-fold (0.08 log units) above what was measured; low and high end bracket the measured number.
By their numbers in the thyroid hormone receptor alpha assay, from the lowest: compounds 1 and 4 (each within the scatter of the next); then compound 2. At a limit, above all of these: compound 3.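

Among these compounds, in the thyroid hormone receptor alpha assay, compound 1 gives 19200 nM and compound 4 gives 33200 nM; the first measured step at this position, a 1.7-fold higher number from compound 1 to compound 4 (0.24 log units; within the scatter), means that the two compounds cannot be told apart, so the carboxylic acid of the 2-carboxyethenyl group is not required for a reading at this level, and a smaller oxiran-2-yl group on the same carbonyl carbon serves equally well in this one pair. In a physicochemical assay for solubility, in phosphate buffer (on this read-out higher numbers stand for higher solubility and lower numbers for lower solubility), compound 1 gives 252000 nM and compound 4 gives 204000 nM; the same exchange gives a 1.2-fold lower number from compound 1 to compound 4 (0.09 log units; within the scatter), so solubility in phosphate buffer does not separate the pair either, and the loss of the hydrogen-bond donor leaves no mark beyond the scatter on either read-out. Nothing measured here gives a cause for either step.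

As far as these compounds go, whether a cyclopropyl group on a carbonyl carbon would read the same as oxiran-2-yl remains open, and with it the question of whether the oxygen of the three-membered ring counts at all. Equally open, from the compounds shown here alone, is what a butyl or an octyl chain in place of hexyl would do to compound 1 and compound 4, and whether the two would still read alike.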